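Swapping the acetylated amine for a secondary amine chain

The compounds below may be only part of what the source reports. "The series", "measured", "known", "first", "only" and "open" are said of these compounds alone.

Measured compounds:
- Compound 1, `C#CCN(CC)Cc1cn(-c2cc(NC(=S)NCC)ncn2)cn1`: 6.71%
- Compound 2, `C#CCN(Cc1cn(-c2cc(NC(=S)NCC)ncn2)cn1)C(C)=O`: 4.83%

In an assay on isolated protein for inhibition of Amine oxidase [flavin-containing] A (Homo sapiens), read by fluorescence and Amplex Red, with a stated time of 15 min, tested at 50 uM (on this read-out lower numbers stand for less inhibition and higher numbers for more inhibition at the one concentration tested (going by the name of the read-out)), compound 1 gives 6.71% and compound 2 gives 4.83%. Compound 2 has the lower of the two numbers, but the step of a number 1.9 percentage points lower from compound 1 to compound 2 (within the scatter) is within the scatter, so the two compounds are not distinguishable. Compound 3, `C#CCNCCCc1cn(-c2cc(NC(=S)NCC)ncn2)cn1`, is not yet measured. It differs from compound 2 in that (a group of 6 heavy atoms (5 carbon, 1 nitrogen; no ring) in place of a group of 7 heavy atoms (5 carbon, 1 nitrogen, 1 oxygen; no ring), on a saturated chain carbon bound to an aromatic carbon); the 2-(propargylamino)ethyl group replaces the acetyl-bearing group.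

For the measured compounds named here, the only measured step, a number 1.9 percentage points lower from compound 1 to compound 2 (within the scatter), also changes the group on this amine nitrogen, and it stayed within the scatter. With both measured values low, no step beyond the scatter is expected for compound 3 in this assay, so the estimated step is a number 2.2 percentage points higher from compound 2 to compound 3 (within the scatter). Compound 3 is therefore expected to give about 7%, within a range from 0% to 20%.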

Compound 3, a percentage reported as inhibition, at one concentration (the size of the read-out at that concentration, not a potency): 31.4%
For compound 3 the middle estimate is 24.4 percentage points below the measured one; the whole stated range lies below it.
By their numbers in this assay, from the lowest: compounds 2 and 1 (each within the scatter of the next); then compound 3.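

In this assay, the 2-(propargylamino)ethyl group on a saturated chain carbon bound to an aromatic carbon gives a number 26.6 percentage points higher from compound 2 to compound 3 (beyond the scatter), and also a number 24.7 percentage points higher from compound 1 to compound 3 (beyond the scatter). This shows that changes at this place can move the number beyond the scatter, which the exchange of ethyl for acetyl did not show. The entering group also carries a hydrogen-bond donor that the group it replaces in compound 2 lacks, but nothing here establishes why the number rose.

The compounds shown leave open whether the rise follows from that amine hydrogen or from the altered chain, and a methyl group on the same amine nitrogen or a longer chain would help separate the two. As far as these compounds go, how potent compound 3 is also stays open, since its number comes from a single concentration.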